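The compounds below may be only part of what the source reports. "The series", "measured", "known", "first", "only" and "open" are said of these compounds alone.

Compound 1 `CC(C)CC[C@@]1(NCc2ccccc2)C(=O)C(C2=NS(=O)(=O)c3cc(NS(C)(=O)=O)ccc3N2)=C(O)c2ccccc21` is one of three compounds that have been measured in an in vivo ADME assay on the whole organism (strain Sprague-Dawley) for pharmacokinetics, with Rattus norvegicus as the target, at a dose of 5 mg/kg by the intravenous route (on this read-out higher numbers stand for fast clearance and lower numbers for slow clearance), in which compound 1 gives 19.3 mL/min/kg. Its two companions keep the same core and the same saturated chain on the ring carbon but carry a different group on the chain carbon bound to the amine nitrogen: compound 2 `Cc1ccc(CNC2(CCC(C)(C)C)C(=O)C(C3=NS(=O)(=O)c4cc(NS(C)(=O)=O)ccc4N3)=C(O)c3ccccc32)cn1` gives 98.3 mL/min/kg, and compound 3 `Cc1cccc(CNC2(CCC(C)(C)C)C(=O)C(C3=NS(=O)(=O)c4cc(NS(C)(=O)=O)ccc4N3)=C(O)c3ccccc32)n1` gives 28.3 mL/min/kg. Compound 1 has the lowest number of the three; the gap to compound 3 lies within the scatter, while the gap to compound 2 lies beyond it. For the measured compounds named here, the only step measured between neighbours is a 3.5-fold lower number from compound 2 to compound 3 (0.54 log units; beyond the scatter), which exchanges one ring for another on that chain carbon.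

Compound 4 `CC(C)CC[C@@]1(N)C(=O)C(C2=NS(=O)(=O)c3cc(NS(C)(=O)=O)ccc3N2)=C(O)c2ccccc21` differs from compound 1 in a different way: hydrogen in place of benzyl on an amine nitrogen, which cuts the benzylamino down to amino. Going by the values given here, no measured step removes this group, so the only guide is the size of the swap in a 3.5-fold lower number from compound 2 to compound 3 (0.54 log units; beyond the scatter), which shows that changes at this position can move the number modestly, in either direction. Compound 4 is therefore expected to land near compound 1, with a 1.0-fold higher number from compound 1 to compound 4 (0.02 log units; within the scatter) assumed, giving an estimate of 20 mL/min/kg and a range from 7 mL/min/kg to 55 mL/min/kg.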

Compound 4, clearance: 35.3 mL/min/kg
The estimate for compound 4 lay 1.8-fold (0.25 log units) below the measured number; the range from low to high includes it.
By their numbers in this assay, from the lowest: compounds 1, 3 and 4 (each within the scatter of the next); then compound 2.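

Taking the whole benzyl group off the amine nitrogen, leaving only amino on the saturated ring carbon, gives a 1.8-fold higher number from compound 1 to compound 4 (0.26 log units; within the scatter) in this assay, so the aromatic ring and all seven carbons of the benzyl can go without a change that stands out from the scatter. For the compounds shown here, the earlier compounds showed only that exchanging one ring for another at this place can matter, with a 3.5-fold lower number from compound 2 to compound 3 (0.54 log units; beyond the scatter), and they could not show what happens with no ring at all; the pair of compound 1 and compound 4 shows that, on the core and chain of compound 1, the ring is not required for a number in this range. No measurement is at hand that would explain why this step stays so small.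

Going by these compounds, what remains open is how a small group such as methyl or acetyl, or a larger one such as a carboxylic acid on a longer chain, would behave on this amine nitrogen. Also open, on these data alone, is whether the free amino group would give a similar result on the chain carried by compound 2 and compound 3, where the ring exchange on the amine side made a clear difference.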